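Para-substituted benzyl triazoles on a shared deoxynucleoside core

The source may report more compounds than this note shows. Statements on the series, on what has been measured and on what is new or still open speak of the compounds shown alone.

Measured compounds:
compound 1, `CC(=O)OC[C@H]1O[C@@H](n2cc(-c3cn(Cc4ccc(C(C)C)cc4)nn3)c(=O)[nH]c2=O)C[C@@H]1OC(C)=O`, gives 95.4% in a functional assay on NUGC-3 cells (Homo sapiens) for cytotoxicity, read by sulforhodamine B assay, tested at 10 uM; a lower number here means less inhibition, a higher number more inhibition at the concentration tested (going by the name of the read-out)
compound 2, `CCc1ccc(-c2cc(-c3cn([C@H]4C[C@H](OC(C)=O)[C@@H](COC(C)=O)O4)c(=O)[nH]c3=O)on2)cc1`, gives 72.6%
compound 3, `CC(=O)OC[C@H]1O[C@@H](n2cc(-c3cn(Cc4ccccc4)nn3)c(=O)[nH]c2=O)C[C@@H]1OC(C)=O`, gives 88.7%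

Compound 3 stands second highest of the three numbers. For the measured compounds named here, its nearest neighbour is compound 1, which lies higher by a margin within the scatter; compound 2 lies furthest away, lower by a margin beyond the scatter, but no single-point step connects compound 2 to the others.

Compound 4, `CC(=O)OC[C@H]1O[C@@H](n2cc(-c3cn(Cc4ccc(C(C)(C)C)cc4)nn3)c(=O)[nH]c2=O)C[C@@H]1OC(C)=O`, is to be measured. It differs from compound 3 by tert-butyl in place of hydrogen on an aromatic carbon.

Going by the values given here, one measured step bears on this: a number 6.7 percentage points lower from compound 1 to compound 3 (within the scatter), which is within the scatter. Among the compounds with values here, that step concerns isopropyl at the same aromatic carbon, so it is the only guide for a larger alkyl group there. Reversing its direction and allowing for a bulkier alkyl group, the expected step of a number 3.3 percentage points higher from compound 3 to compound 4 (within the scatter) is small, upward at most, and not clearly beyond the scatter.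

Compound 4 is therefore estimated at 92%, with a range from 80% to 99%.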

Compound 4, a percentage reported as inhibition, at one concentration (the size of the read-out at that concentration, not a potency): 94.2%
Compound 4: the middle estimate sits 2.2 percentage points below what was measured; the range from low to high includes it.
By their numbers in this assay, from the lowest: compound 2; then compounds 3, 4 and 1 (each within the scatter of the next).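

In this assay, going from benzyl to 4-(tert-butyl)benzyl gives a number 5.5 percentage points higher from compound 3 to compound 4 (within the scatter), so this aromatic carbon now has a second branched alkyl group, after isopropyl, whose step from hydrogen stays inside the scatter. For the compounds shown here, the extra methyl that separates the two branched groups gives a number 1.2 percentage points lower from compound 1 to compound 4 (within the scatter), so among hydrogen, isopropyl and tert-butyl at this position, no step leaves the scatter. Nothing available accounts for these numbers.

Still open, from the compounds shown here alone, is whether a group of another kind on this carbon, such as an amine, a carboxylic acid or a longer chain, would give a step beyond the scatter. Readings at a single concentration also give no potency for any of these compounds, so any differences among them that this read-out cannot separate stay unresolved.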